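The source may hold more compounds than are shown below. What is called first, only, known or untested is meant among the compounds shown, and "the series" means these compounds.

In a functional assay on HeLa cells (Homo sapiens) for inhibition, read by sulforhodamine B assay (on this read-out lower numbers stand for stronger inhibition and higher numbers for weaker inhibition), compound 3 `COc1ccccc1NC1=CC(=O)c2nc3n(c2C1=O)[C@H]1OC[C@@H](O)[C@H]1OC3` gives 2950 nM and compound 1 `O=C1C=C(Nc2ccccc2F)C(=O)c2c1nc1n2[C@H]2OC[C@@H](O)[C@H]2OC1` gives 5120 nM, a pair within the scatter of each other. Compound 2 `O=C1C=C(NC2CCCCC2)C(=O)c2c1nc1n2[C@H]2OC[C@@H](O)[C@H]2OC1` gives > 16000 nM in this assay, which is a limit. Compound 4 `Cc1ccc(NC2=CC(=O)c3nc4n(c3C2=O)[C@H]2OC[C@@H](O)[C@H]2OC4)cc1C` differs from compound 3 by 3,4-dimethylphenyl in place of 2-methoxyphenyl on an amine nitrogen. Changing the substituent on the phenyl ring gave a 1.7-fold lower number from compound 1 to compound 3 (0.24 log units; within the scatter), within the scatter. Replacing the phenyl ring with cyclohexyl, or the reverse, gave larger steps: an at least 3.1-fold higher number from compound 1 to compound 2 (0.49 log units; beyond the scatter) and an at least 5.4-fold lower number from compound 2 to compound 3 (0.73 log units; beyond the scatter). Compound 4 keeps a phenyl ring on that nitrogen, so no step beyond the scatter is expected in this assay. The expected step is a 1.0-fold higher number from compound 3 to compound 4 (0.01 log units; within the scatter). For compound 4 the estimated value is 3000 nM, with an expected range of 1000 nM to 9000 nM.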

Compound 4, half-maximal inhibitory concentration: 2690 nM
Compound 4: the middle estimate sits 1.1-fold (0.05 log units) above what was measured, and the stated range covers the measured number.
By their numbers in this assay, from the lowest: compounds 4, 3 and 1 (each within the scatter of the next). At a limit, above all of these: compound 2.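

In this assay, 3,4-dimethylphenyl on the amine nitrogen, which carries no oxygen, serves as well as the 2-methoxyphenyl of compound 3, with a 1.1-fold lower number from compound 3 to compound 4 (0.04 log units; within the scatter), and the 2-fluorophenyl of compound 1, with a 1.9-fold lower number from compound 1 to compound 4 (0.28 log units; within the scatter). This third aryl group also stands apart from cyclohexyl, with an at least 5.9-fold lower number from compound 2 to compound 4 (0.77 log units; beyond the scatter). Compound 2 is a limit, not a number: the limit of > 16000 nM in this assay, at which 1 of the 4 values shown sits.

Open remains how a carboxylic acid or dimethylamino group on the phenyl ring, or a benzyl group on the amine nitrogen, would read. Also open, as far as these compounds go, is whether any aryl group can move the number beyond the scatter.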